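Ester for phenyl on the shared core: outlook for compound 4

The source may report more compounds than this note shows. Statements on the series, on what has been measured and on what is new or still open speak of the compounds shown alone.

Compound 1 `CCCCCCCCc1ccc(OCC(=O)Cn2nnc(-c3ccccc3)n2)cc1` is the reference point. Among the compounds with values here, in an assay on microsomes from brain for inhibition of Fatty-acid amide hydrolase 1 (Rattus norvegicus), read by fluorescence and HPLC, with a stated time of 60 min (on this read-out higher numbers stand for weaker inhibition and lower numbers for stronger inhibition), compound 1 gives 24 nM, the second highest of the three numbers so far; compound 2 `CCCCCCCCc1ccc(OCC(=O)Cn2nnc(-c3ccccn3)n2)cc1` gives 18 nM and compound 3 `CCCCCCCCc1ccc(OCC(=O)Cn2nnc(C(=O)O)n2)cc1` gives 41 nM. Both a 1.3-fold lower number from compound 1 to compound 2 (0.12 log units; within the scatter) and a 1.7-fold higher number from compound 1 to compound 3 (0.23 log units; within the scatter) stay within the scatter, while a 2.3-fold higher number from compound 2 to compound 3 (0.36 log units; beyond the scatter) is modest but beyond it.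

Compound 4 `CCCCCCCCc1ccc(OCC(=O)Cn2nnc(C(=O)OC)n2)cc1` differs from compound 1 as follows: methoxycarbonyl in place of phenyl on an aromatic carbon. The nearest measured guide is compound 3, whose step a 1.7-fold higher number from compound 1 to compound 3 (0.23 log units; within the scatter) lay within the scatter; the carboxy group entering there is closest in kind to the methoxycarbonyl entering in compound 4. The other change at the same place, a 1.3-fold lower number from compound 1 to compound 2 (0.12 log units; within the scatter), also moved little. Within the data shown here, no measured step therefore points to a large shift, and the expectation in this assay is a number near compound 1 and compound 3, if anything somewhat higher.

For compound 4 the expected step is a 1.5-fold higher number from compound 1 to compound 4 (0.16 log units; within the scatter). Compound 4 is estimated at 35 nM in this assay, with a range from 15 nM to 80 nM.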

Compound 4, half-maximal inhibitory concentration: 88 nM
Beside the measured number, compound 4's estimate is 2.5-fold (0.40 log units) below it, outside the stated range (above it).
By their numbers in this assay, from the lowest: compounds 2, 1 and 3 (each within the scatter of the next, the first and the last beyond it); then compound 4.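

In this assay this place, on an aromatic carbon of a five-membered aromatic ring with 4 nitrogen, now gives a step beyond the scatter from compound 1: methoxycarbonyl in place of phenyl gives a 3.7-fold higher number from compound 1 to compound 4 (0.56 log units; beyond the scatter), and methoxycarbonyl in place of pyridin-2-yl gives a 4.9-fold higher number from compound 2 to compound 4 (0.69 log units; beyond the scatter). The carboxy group and its methyl ester are also told apart here, with methyl in place of hydrogen on the oxygen giving a 2.1-fold higher number from compound 3 to compound 4 (0.33 log units; beyond the scatter), so compound 4 is the weakest inhibitor of the four. Nothing available explains this loss.

An ethyl ester, a primary amide or a methyl ketone at this place would help show whether the loss follows the methyl on oxygen or a wider range of carbonyl groups. As far as these compounds go, whether a nitrile or a small alkyl group here would stay near compound 1 remains open.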